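Working notes: a third rearranged bicycle on the amide arm

The source may report more compounds than this note shows. Statements on the series, on what has been measured and on what is new or still open speak of the compounds shown alone.

Compound 1 `O=C1CN(S(=O)(=O)c2cc3ccc(Cl)cc3s2)CCN1Cc1cc2c[nH]ccc-2n1` and compound 2 `O=C1CN(S(=O)(=O)c2cc3ccc(Cl)cc3s2)CCN1Cc1cc2[nH]cccc-2n1` share the same core and differ only in the group of 9 heavy atoms on a saturated chain carbon bound to an amide-type nitrogen in a ring. In an assay on isolated protein for binding affinity to serine protease 1 (Homo sapiens) (a lower number here means a stronger inhibitor, a higher number a weaker inhibitor), compound 1 gives only a limit, > 2900 nM. In this assay compound 2 likewise gives only a limit, > 2900 nM. The step that the two limits leave unreadable from compound 1 to compound 2 is therefore not readable, and both values sit at the limit of > 2900 nM in this assay, at which 2 of the 2 values shown sit.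

Compound 3 `O=C1CN(S(=O)(=O)c2cc3ccc(Cl)cc3s2)CCN1Cc1cc2cc[nH]cc-2n1` carries the change (a group of 9 heavy atoms (7 carbon, 2 nitrogen; one five-membered aromatic ring with 1 hetero atom, one six-membered aromatic ring with 1 hetero atom) in place of a group of 9 heavy atoms (7 carbon, 2 nitrogen; one five-membered aromatic ring with 1 hetero atom, one six-membered aromatic ring with 1 hetero atom), on a saturated chain carbon bound to an amide-type nitrogen in a ring); the two have the same atoms, joined differently. For the measured compounds named here, the only measured step that bears on this kind of change, the one from compound 1 to compound 2, gives no size, so no direction can be drawn from it. With both neighbours at the limit, the expected step that the limit leaves unreadable from compound 2 to compound 3 is none beyond the scatter, most likely ending again at a limit. For compound 3 the estimate in this assay is 6000 nM, with a range of 2900 nM to 20000 nM.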

Compound 3, inhibition constant: > 2900 nM
Compound 3: a limit, no number (the forecaster's own chance of this, stated with the estimate: 80%); the middle value does not contradict the limit.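

In this assay compound 3 gives > 2900 nM, again a limit and not a number. No step among compound 1, compound 2 and compound 3 can be read: the limit of > 2900 nM in this assay, at which 3 of the 3 values shown sit.

The compounds shown leave open whether these three differently joined groups differ at all in inhibition of the protease, since none has a numerical value.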